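Series notes: cytotoxicity so far and the pending compound 4

The source may hold more compounds than are shown below. What is called first, only, known or untested is meant among the compounds shown, and "the series" means these compounds.

In an ADME assay on BHK-21 cells (Mesocricetus auratus) for cytotoxicity, read by MTT assay, with a stated time of 72 h (on this read-out lower numbers stand for higher toxicity in this test and higher numbers for lower toxicity in this test), compound 1 `NS(=O)(=O)c1ccc(N2N=C(c3ccc(OCc4ccccc4)cc3)CC2c2ccccc2Cl)cc1` gives 12000 nM, compound 2 `Cc1ccc(C2CC(c3ccc(OCc4ccccc4)cc3)=NN2c2ccc(S(N)(=O)=O)cc2)cc1` gives 32000 nM and compound 3 `Cc1ccc(C2CC(c3ccc(Oc4ccccc4)cc3)=NN2c2ccc(S(N)(=O)=O)cc2)cc1` gives 8000 nM. Compound 3 has the lowest number of the three, but its gap to compound 1 is within the scatter, so no order between those two is read. Both measured steps run from compound 2: a 2.7-fold lower number from compound 2 to compound 1 (0.43 log units; beyond the scatter), where the change is 2-chlorophenyl in place of 4-methylphenyl on a saturated ring carbon, and a 4.0-fold lower number from compound 2 to compound 3 (0.60 log units; beyond the scatter).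

Compound 4 `NS(=O)(=O)c1ccc(N2N=C(c3ccc(Oc4ccccc4)cc3)CC2c2ccccc2Cl)cc1` has not been measured in this assay. It stands to compound 3 as compound 1 stands to compound 2: 2-chlorophenyl in place of 4-methylphenyl on a saturated ring carbon. The place description matches word for word, so this is the same change made a second time, now on the core of compound 3; that core and the core of compound 2 differ by phenyl in place of benzyl on an oxygen on an aromatic ring. The expectation rests on the earlier step: because a 2.7-fold lower number from compound 2 to compound 1 (0.43 log units; beyond the scatter) lowered the number modestly, a step of similar size is expected, a 2.3-fold lower number from compound 3 to compound 4 (0.36 log units; beyond the scatter). Compound 4 is accordingly estimated at 3500 nM, with a range of 1500 nM to 9000 nM.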

Compound 4, half-maximal cytotoxic concentration: 8000 nM
Estimate against measurement, compound 4: 2.3-fold (0.36 log units) below; the measured number falls inside the stated range.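

In this assay, 2-chlorophenyl in place of 4-methylphenyl on a saturated ring carbon gives no change at the digits printed from compound 3 to compound 4 (within the scatter), so this change does not carry over from the core of compound 2 to the core of compound 3 at a constant size: the same change on two cores in this assay, a 2.7-fold lower number (0.43 log units; beyond the scatter) from compound 2 to compound 1 and no change at the digits printed (within the scatter) from compound 3 to compound 4, 2.7-fold (0.43 log units) apart, beyond the scatter of two such steps. Phenyl in place of benzyl on an oxygen on an aromatic ring gives a 1.5-fold lower number from compound 1 to compound 4 (0.18 log units; within the scatter), so that change does not carry over at a constant size either, now between the cores of compound 2 and compound 1: the same change on two cores in this assay, a 4.0-fold lower number (0.60 log units; beyond the scatter) from compound 2 to compound 3 and a 1.5-fold lower number (0.18 log units; within the scatter) from compound 1 to compound 4, 2.7-fold (0.43 log units) apart, beyond the scatter of two such steps. These results show that neither step can be treated as a fixed increment across these compounds, but they do not explain the difference, and a single set of compounds on two pairs of cores does not predict the size of either step on another core.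

Still open, as far as these compounds go, is how the number moves when the group on the saturated ring carbon carries an amine or a carboxylic acid. Equally open, from the compounds shown here alone, is how it moves when the group on the oxygen is a longer chain, such as phenylpropyl.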